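Two macrocyclic lactones and an ester variant awaiting cytotoxicity testing

A few compounds are considered here, and "the series" means these few. Any claim that something is new, unique, unknown or untested is made for them only; others in the source may bear on it.

Measured so far:
- compound 1, `C=C1C(=O)O[C@H]2C/C(C)=C/[C@@H](O)C/C(C)=C/CC/C(C)=C/C[C@H]12`: > 5 ug/mL in a functional assay on MDA-MB-231 cells (Homo sapiens) for cytotoxicity, read by MTT assay; on this read-out lower numbers stand for stronger inhibition and higher numbers for weaker inhibition
- compound 2, `C=C1C(=O)O[C@H]2/C=C(\C)CC/C=C(\CO)CC/C=C(\C)CC[C@@H]12`: > 5 ug/mL in this assay

Compound 1 gives in this assay only a limit, not a number. Compound 2 likewise gives only a limit, not a number. Going by the values given here, both of the values known here sit at that same limit, as summed up by the limit of > 5 ug/mL in this assay, at which 2 of the 2 values shown sit, so compound 2 stands level with the one other compound and no order between them can be stated.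

Compound 3, `C=C1C(=O)O[C@H]2/C=C(\C)CC/C=C(\C(=O)OC)CC/C=C(\C)CC[C@@H]12`, has not been tested. It differs from compound 2 in one place: methoxycarbonyl in place of hydroxymethyl on a double-bonded ring carbon. The hydroxymethyl, with its one hydrogen-bond donor, leaves, and a methoxycarbonyl with two hydrogen-bond acceptors enters on a double-bonded ring carbon of the large carbon-only ring.

Among the compounds with values here, no measured step with a number is available to guide the size of this change. Given that compound 2 sits at the limit, the expected step that the limit leaves unreadable from compound 2 to compound 3 is none beyond the scatter. Compound 3 is therefore estimated at 8 ug/mL in this assay, within 3 ug/mL to 25 ug/mL, with a fair chance that again only a limit is reported.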

Compound 3, half-maximal inhibitory concentration: > 5 ug/mL
Compound 3: no number, only a limit; the forecaster's own chance of this, stated with the estimate: 60%; the middle value lies beyond the limit too.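

Going by these compounds alone, compound 2 and compound 3 each give only a limit in this assay, not a number, and no step between them can be read. The three compounds shown therefore have no order: the limit of > 5 ug/mL in this assay, at which 3 of the 3 values shown sit.

Going by these compounds, what stays open is where the true value of each compound lies, and whether exchanging hydroxymethyl for methoxycarbonyl changes cytotoxicity at all.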